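Replacing the arylsulfanyl group with butylsulfanyl in the series

The source may report more compounds than this note shows. Statements on the series, on what has been measured and on what is new or still open speak of the compounds shown alone.

In a functional assay on HepG2 cells (Homo sapiens) for cytotoxicity, read by MTT assay, with a stated time of 48 h (a higher number here means a weaker inhibitor, a lower number a stronger inhibitor), compound 1 `O=C(CSc1ccccc1)N1N=C(c2cc3ccccc3oc2=O)C[C@@H]1c1ccccc1` gives 16300 nM, compound 2 `O=C(CSc1ccc(Br)cc1)N1N=C(c2cc3ccccc3oc2=O)C[C@@H]1c1ccccc1C(F)(F)F` gives 17900 nM, and compound 3 `O=C(CSc1ccc(Br)cc1)N1N=C(c2cc3ccccc3oc2=O)C[C@@H]1c1ccccc1` gives 14500 nM. Compound 3 therefore stands level with the other two, as both of its steps lie within the scatter. Bromo in place of hydrogen on an aromatic carbon gives a 1.1-fold lower number from compound 1 to compound 3 (0.05 log units; within the scatter), and hydrogen in place of trifluoromethyl on an aromatic carbon gives a 1.2-fold lower number from compound 2 to compound 3 (0.09 log units; within the scatter).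

The change under consideration leads to compound 4 `CCCCSCC(=O)N1N=C(c2cc3ccccc3oc2=O)C[C@@H]1c1ccccc1`, with butyl in place of 4-bromophenyl on a sulfur. For the measured compounds named here, all three measured compounds keep an aromatic ring on that sulfur, so no measured step tests this exchange directly. The nearest evidence is the bromo step on that ring, a 1.1-fold lower number from compound 1 to compound 3 (0.05 log units; within the scatter), which says nothing about losing the ring itself. No step beyond the scatter is expected in this assay, with a slight lean towards a higher number. The expected step is a 1.4-fold higher number from compound 3 to compound 4 (0.14 log units; within the scatter). For compound 4 the estimated value is 20000 nM, with an expected range from 9000 nM to 45000 nM.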

Compound 4, half-maximal inhibitory concentration: 6640 nM
Compound 4: middle estimate off by 3.0-fold (0.48 log units), on the high side; measured number below the stated range.
By their numbers in this assay, from the lowest: compound 4; then compounds 3, 1 and 2 (each within the scatter of the next).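

In this assay an aromatic ring on the sulfur is not needed to hold the number: butyl in place of 4-bromophenyl gives a 2.2-fold lower number from compound 3 to compound 4 (0.34 log units; beyond the scatter) and butyl in place of phenyl gives a 2.5-fold lower number from compound 1 to compound 4 (0.39 log units; beyond the scatter) with both steps modest. For the compounds shown here, these two are the only steps in the set that lie beyond the scatter, while the bromo exchange on the ring gives only a 1.1-fold lower number from compound 1 to compound 3 (0.05 log units; within the scatter) so at this position replacing the ring moves the number where substituting it does not. Nothing measured here accounts for the lower number with butyl, and the shift stands as an observation without an explanation.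

Open, going by these compounds, is whether the lower number follows from the butyl chain itself or simply from the absence of the ring, a question that a shorter ethyl chain, a longer octyl chain or a benzyl group on the sulfur would help to separate. Also open, on these data alone, is whether the butyl exchange carries over to the compound with trifluoromethyl on the aromatic carbon, and how a chain ending in an amine or a carboxylic acid would read in this assay at this sulfur.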